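Chloro in place of methyl on the sulfonyl aryl ring

The source may hold more compounds than are shown below. What is called first, only, known or untested is meant among the compounds shown, and "the series" means these compounds.

Measured so far in an assay on isolated protein for displacement of a labelled ligand from metabotropic glutamate receptor 5 (Homo sapiens), with a stated time of 60 min, tested at 1 uM; on this read-out lower numbers stand for less inhibition and higher numbers for more inhibition at the one concentration tested (going by the name of the read-out):
compound 1 `CC1CCN(c2c(S(=O)(=O)c3cccc(Cl)c3)cnc3ccc(Cl)cc23)CC1`: 92%
compound 2 `Cc1ccc(S(=O)(=O)c2cnc3cc(Cl)ccc3c2N2CCC(C)CC2)cc1C`: 86%

Compound 2 carries the lower of the two numbers in this assay, but compound 1 sits only a margin within the scatter above it, so the two cannot be ranked. Compound 3 `Cc1ccc(S(=O)(=O)c2cnc3cc(Cl)ccc3c2N2CCC(C)CC2)cc1Cl` is not yet measured; it differs from compound 2 by chloro in place of methyl on an aromatic carbon. Among the compounds with values here, no step between measured compounds is known here. For compound 3 a step of a number 1 percentage points lower from compound 2 to compound 3 (within the scatter) is expected, none beyond the scatter. Compound 3 is estimated at 85%, between 70% and 96%.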

Compound 3, a percentage reported as inhibition, at one concentration (the size of the read-out at that concentration, not a potency): 89%
For compound 3 the middle estimate is 4 percentage points below the measured one, within the range that was stated.
By their numbers in this assay, from the lowest: compounds 2, 3 and 1 (each within the scatter of the next).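

In this assay, replacing 3,4-dimethylphenyl with 3-chloro-4-methylphenyl gives a number 3 percentage points higher from compound 2 to compound 3 (within the scatter), so chloro and methyl cannot be separated on this aromatic carbon, ortho to a methyl group. Within the data shown here, this pair gives the first one-place comparison, and at this position the swap leaves the read-out unchanged within the scatter. No supporting data bear on this result.

Going by these compounds, whether an amine, a carboxylic acid or a methoxy group on this carbon would keep the read-out remains open. A single tested concentration also leaves any potency difference between compound 2 and compound 3 unresolved.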